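This account rests on a few compounds, and the source may have more. Where it says the series, first, only, none or still open, it means among the compounds named here.

Measured compounds:
- compound 1, `CNc1nc(-n2cc(-c3ccccn3)nn2)nc2c1ncn2[C@@H]1O[C@H](CO)[C@@H](O)[C@H]1O`: 10.3 nM
- compound 2, `CCNC(=O)[C@H]1O[C@@H](n2cnc3c(NC)nc(-n4cc(Cc5ccccc5)nn4)nc32)[C@H](O)[C@@H]1O`: 2.8 nM
- compound 3, `CNc1nc(-c2cn(Cc3cccc(Cl)c3)nn2)nc2c1ncn2[C@@H]1O[C@H](CO)[C@@H](O)[C@H]1O`: 81.1 nM

In an assay on CHO cells for displacement of a labelled ligand from adenosine receptor A3 (Homo sapiens) (on this read-out higher numbers stand for weaker inhibition and lower numbers for stronger inhibition), compound 1 gives 10.3 nM, which places it second highest of the three numbers. Compound 2 sits lower, with 2.8 nM, a gap beyond the scatter, while compound 3 sits higher at 81.1 nM, also beyond the scatter. Compound 1 is therefore neither the strongest nor the weakest binder of the three.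

Compound 4, `CNc1nc(-n2cc(CC3CCCCC3)nn2)nc2c1ncn2[C@@H]1O[C@H](CO)[C@@H](O)[C@H]1O`, differs from compound 1 in one place: cyclohexylmethyl in place of pyridin-2-yl on an aromatic carbon. The aromatic pyridin-2-yl is exchanged for a saturated cyclohexylmethyl, on an aromatic carbon of a five-membered aromatic ring with three nitrogen atoms, next to the ring nitrogen. Going by the values given here, no measured pair shows this exact exchange, so the size of the step has to be estimated. Compound 2, which carries a benzyl group at a comparable spot and gives 2.8 nM, suggests that a one-carbon-linked ring is tolerated here. A small step is expected from compound 1 to compound 4, a 1.5-fold higher number from compound 1 to compound 4 (0.16 log units; within the scatter), within the scatter. Compound 4 is expected to give 15 nM, in a range from 4 nM to 60 nM.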

Compound 4, inhibition constant: 21.3 nM
Compound 4: the middle estimate sits 1.4-fold (0.15 log units) below what was measured; the measured number falls inside the stated range.
By their numbers in this assay, from the lowest: compound 2; then compound 1; then compound 4; then compound 3.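

In this assay, going by these compounds alone, the exchange of pyridin-2-yl for cyclohexylmethyl gives a 2.1-fold higher number from compound 1 to compound 4 (0.32 log units; beyond the scatter) and is the only change here that can be read on its own. It shows that this aromatic carbon of the five-membered ring can carry a saturated, carbon-only ring in place of an aromatic ring with a hydrogen-bond acceptor, at a modest cost in binding. Nothing available explains why the number rises.

As far as these compounds go, this single step changes the ring type, the ring nitrogen and the carbon link together, so the share of each in the rise remains unknown. From the compounds shown here alone, it also remains open how phenyl, a longer chain such as cyclohexylethyl, or a cyclohexyl ring bearing an amine would behave at this position.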